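Ring Swap on the Oxazole of a Piperidine Amide Series

The source may report more compounds than this note shows. Statements on the series, on what has been measured and on what is new or still open speak of the compounds shown alone.

Measured so far:
Compound 1, `Cc1ccccc1-c1nc(CN2CCC(C(=O)NCCCN3CCC(C)(C)CC3)CC2)c(C)o1`, 241 10^-6 cm/s
Compound 2, `Cc1cccc(F)c1-c1nc(CN2CCC(C(=O)NCCCN3C[C@H](C)C[C@H](C)C3)CC2)c(C)o1`, 234 10^-6 cm/s

In a physicochemical assay for permeability, using PAMPA (on this read-out lower numbers stand for lower permeability and higher numbers for higher permeability), compound 1 gives 241 10^-6 cm/s, and compound 2 gives 234 10^-6 cm/s. Compound 2 has the smaller of the two numbers, but the gap to compound 1 is within the scatter of this assay, so the two compounds cannot be told apart on this read-out.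

Compound 3, `Cc1cc(C)cc(-c2nc(CN3CCC(C(=O)NCCCN4C[C@H](C)C[C@H](C)C4)CC3)c(C)o2)c1`, has not yet been measured. It differs from compound 2 in one place: 3,5-dimethylphenyl in place of 2-fluoro-6-methylphenyl on an aromatic carbon. Both the group that leaves and the group that enters are uncharged aromatic rings with no hydrogen-bond donors or acceptors, and the rest of the shared core is untouched.

Within the data shown here, no step between measured compounds in this assay involves a change of this kind, so there is nothing to set a direction from. With the two measured compounds sitting within the scatter of each other despite differing at this ring, compound 3 is expected to stay within the scatter of compound 2, so the estimated step is a 1.0-fold higher number from compound 2 to compound 3 (0.00 log units; within the scatter). For compound 3 the expected value in this assay is 235 10^-6 cm/s, with a range from 150 10^-6 cm/s to 360 10^-6 cm/s.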

Compound 3, apparent permeability: 864 10^-6 cm/s
Compound 3: the middle estimate sits 3.7-fold (0.57 log units) below what was measured; measured number outside the range, above it.
By their numbers in this assay, from the lowest: compounds 2 and 1 (each within the scatter of the next); then compound 3.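

In this assay, the aromatic carbon of the five-membered aromatic ring with 1 nitrogen and 1 oxygen proves to be a place where the read-out can move: 3,5-dimethylphenyl in place of 2-fluoro-6-methylphenyl gives a 3.7-fold higher number from compound 2 to compound 3 (0.57 log units; beyond the scatter), a step beyond the scatter and the only single-place step shown in this series. The size of this step stands out against what the swap leaves unchanged, since both groups are six-membered aromatic rings of carbon with 8 heavy atoms, no hydrogen-bond donors or acceptors and no net charge, so those counts do not separate compound 2 from compound 3. Nothing measured on these compounds speaks to the reason for the step.

The swap removes the fluorine and rearranges the methyl groups in a single change, so the compounds shown leave open which of the two goes with the higher number in this assay. Also open, going by these compounds, are how the read-out would respond to a pyridine ring or a 3,5-dichlorophenyl group on this carbon, and whether 3,5-dimethylphenyl would give a step of similar size with the amine end of compound 1.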